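The source may hold more compounds than are shown below. What is called first, only, known or untested is meant among the compounds shown, and "the series" means these compounds.

Among the compounds with values here, in a physicochemical assay for lipophilicity (a higher number here means a more lipophilic compound, a lower number a more polar compound), compound 3 (`CCCCCCCN(CCCCCSc1nc(N)c2c[nH]nc2n1)C(=O)NC(C)C`) gives 5.14, the lowest of the three numbers so far. Compound 2 (`CCCCCCCN(CCCCCSc1nc(N)c2c[nH]nc2n1)C(=O)Nc1ccc(F)cc1F`) gives 5.74. Compound 4 (`CCCCCCCN(CCCCCSc1[nH]cnc2nncc1-2)C(=O)NC(C)C`) keeps the chains of compound 3 and changes only the group on the sulfur: a group of 9 heavy atoms (5 carbon, 4 nitrogen; one five-membered aromatic ring with 2 hetero atoms, one six-membered aromatic ring with 2 hetero atoms) in place of a group of 10 heavy atoms (5 carbon, 5 nitrogen; one five-membered aromatic ring with 2 hetero atoms, one six-membered aromatic ring with 2 hetero atoms), on a sulfur. Within the data shown here, the single measured step, a number 0.60 log units lower from compound 2 to compound 3 (beyond the scatter), lies elsewhere in the molecule, so it offers only a sense of scale. Compound 1 (`CCCCCCN(CCCCCSc1nc2cc(C)ccc2[nH]1)C(=O)Nc1ccc(F)cc1F`), which has another core and differs in other places too, gives 7.79, a loose hint of upward movement. A modest rise in this assay is therefore expected, and the estimated change is a number 0.36 log units higher from compound 3 to compound 4 (beyond the scatter). Compound 4 is expected at 5.5, with an estimated range of 5 to 6.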

Compound 4, partition coefficient: 5
Compound 4: the middle estimate sits 0.50 log units above what was measured, and the stated range covers the measured number.
By their numbers in this assay, from the lowest: compounds 4 and 3 (each within the scatter of the next); then compound 2; then compound 1.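

With the chains held fixed, the group of 9 heavy atoms on the sulfur in place of the group of 10 heavy atoms gives a number 0.14 log units lower from compound 3 to compound 4 (within the scatter) in this assay. Within the data shown here, this is the first direct reading at this position, and it leaves the two groups indistinguishable in this assay, although the entering group has fewer hydrogen-bond donors and acceptors. Nothing available explains this match. 

On these data alone, a phenyl ring or a carboxylic acid on the sulfur remains untested here. Also open, as far as these compounds go, is whether the same exchange reads alike with the 2,4-difluorophenyl of compound 2 on the amide-type nitrogen.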